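The compounds below may be only part of what the source reports. "The series", "measured", "known", "first", "only" and "open" are said of these compounds alone.

Among the compounds with values here, compound 2, `COc1ccc(F)c(N2CCC(COc3cccc(C(CC(=O)O)C4CC4)c3)CC2)c1`, shows the higher of the two numbers so far: in a functional assay on cells for agonist activity at Free fatty acid receptor 1 (Homo sapiens), read by FLIPR and calcium flux, with a stated time of 60 min (on this read-out lower numbers stand for an effect already at smaller amounts and higher numbers for an effect only at larger amounts of compound), compound 2 gives 670 nM, while compound 1, `COc1ccc(CCCC(C)(C)C)c(-c2ccc(COc3cccc(C(CC(=O)O)C4CC4)c3)cc2)c1`, gives 410 nM in this assay, a gap that the data place within the scatter. Compound 3, `COc1ccc(C(C)C)c(N2CCC(COc3cccc(C(CC(=O)O)C4CC4)c3)CC2)c1`, differs from compound 2 in one place: isopropyl in place of fluoro on an aromatic carbon. Within the data shown here, no measured pair shows this exact change, so the step from compound 2 to compound 3 is expected to be small, at most a modest move toward lower numbers, a 1.9-fold lower number from compound 2 to compound 3 (0.28 log units; within the scatter). Compound 3 is therefore estimated at 350 nM in this assay, within a range from 100 nM to 1200 nM.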

Compound 3, half-maximal effective concentration: 120 nM
Beside the measured number, compound 3's estimate is 2.9-fold (0.46 log units) above it; the measured number falls inside the stated range.
By their numbers in this assay, from the lowest: compound 3; then compounds 1 and 2 (each within the scatter of the next).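

Isopropyl in place of fluoro on this aromatic carbon, ortho to a large group and para to a methoxy group, gives a 5.6-fold lower number from compound 2 to compound 3 (0.75 log units; beyond the scatter) in this assay. Compound 1 and compound 2 differ in more than one place and could not speak to this position, whereas this single change shows that the number depends on the group held there. Nothing shown accounts for the size of this step. Going by these compounds, what a methyl, a cyclopropyl or a trifluoromethyl group would give on this carbon stays open. So does whether the same change would carry over to the core of compound 1.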